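From Hydroxyethyl to Ethyl on Compound 2

The source may hold more compounds than are shown below. What is called first, only, known or untested is meant among the compounds shown, and "the series" means these compounds.

Of the compounds shown here, three have been measured so far in an ADME assay on MRC5 cells (Homo sapiens) for cytotoxicity, read by fluorescence, with a stated time of 24 h (on this read-out higher numbers stand for weaker inhibition and lower numbers for stronger inhibition), and set the scene. There, compound 1 `CC(=O)OCCC1S/C(=N\N=C\c2c(-c3ccccc3)[nH]c3ccccc23)NC1=O` gives 42800 nM as its result. Compound 3 `CCc1nn2c(C=O)c(-c3ccc([N+](=O)[O-])cc3)nc2s1` reads > 50000 nM and this is a limit of the assay, not a number. Compound 2 `O=C1N/C(=N/N=C/c2c(-c3ccc(Br)cc3)[nH]c3ccccc23)SC1CCO` gives 15900 nM as the lowest of the true numbers, a gap from compound 1 that lies beyond the usual scatter.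

Compound 4 `CCC1S/C(=N\N=C\c2c(-c3ccc(Br)cc3)[nH]c3ccccc23)NC1=O` differs from compound 2 in one place: hydrogen in place of hydroxy on a saturated chain carbon, two bonds along the chain from a saturated ring carbon with hydrogen in place of hydroxy on a saturated chain carbon, two bonds along the chain from a saturated ring carbon, so that 2-hydroxyethyl becomes ethyl. Going by the values given here, no measured pair differs in one place alone, so this step has no direct precedent, and no shift beyond the scatter in this assay is expected, in either direction. The estimated step of a 1.1-fold lower number from compound 2 to compound 4 (0.06 log units; within the scatter) is therefore small. For compound 4 the expected value is 14000 nM with an estimated range of 6000 nM to 36000 nM as its likely span.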

Compound 4, half-maximal inhibitory concentration: 5910 nM
The estimate for compound 4 lay 2.4-fold (0.37 log units) above the measured number, and the stated range ends above it.
By their numbers in this assay, from the lowest: compound 4; then compound 2; then compound 1. At a limit, above all of these: compound 3.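

In this assay, the change from 2-hydroxyethyl to ethyl gives a 2.7-fold lower number from compound 2 to compound 4 (0.43 log units; beyond the scatter), and a lower number here means stronger inhibition of the cells. Going by these compounds alone, the earlier compounds differed from one another in more than one place, so this is the first pair to show that this position alone can move the read-out beyond the usual scatter, with the ethyl compound the more strongly inhibiting of the two. Nothing measured here explains why removing the hydroxy has this effect.

The compounds shown leave open how a longer chain such as propyl, or an amine or a carboxylic acid in place of the hydroxy, would read. From the compounds shown here alone, it also remains open whether the same change would give a similar step in a compound without the bromine.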